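A Longer Amine Chain on a Shared Core

The source may report more compounds than this note shows. Statements on the series, on what has been measured and on what is new or still open speak of the compounds shown alone.

Compound 1 `CC(C)NCc1nnc(-c2ccccc2-c2ccccc2)s1`: in a functional assay on the whole organism with Mus musculus as the target (a lower number here means that less compound is needed, a higher number that more compound is needed for the effect), compound 1 gives 35 mg/kg.
Compound 2 `CC(N)c1nnc(-c2ccccc2-c2ccccc2)s1`: compound 2 gives 32 mg/kg.
Compound 3 `CNCc1nnc(-c2ccccc2-c2ccccc2)s1`: compound 3 gives 20 mg/kg.

Compound 3 carries the lowest of the three numbers, yet a 1.8-fold lower number from compound 1 to compound 3 (0.24 log units; within the scatter) and a 1.6-fold lower number from compound 2 to compound 3 (0.20 log units; within the scatter), so no real order among the three can be claimed. Compound 4 `NCCCc1nnc(-c2ccccc2-c2ccccc2)s1` keeps the shared core; the change is 2-aminoethyl in place of methylamino on a saturated chain carbon bound to an aromatic carbon. Among the measured compounds shown here, every measured step so far reshapes the amine-bearing side chain, and each stays within the scatter, a 1.1-fold lower number from compound 1 to compound 2 (0.04 log units; within the scatter) included. The same is therefore expected here: compound 4 is estimated at 22 mg/kg, with a range from 10 mg/kg to 48 mg/kg. That estimate means a 1.1-fold higher number from compound 3 to compound 4 (0.04 log units; within the scatter), a step expected to stay within the scatter.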

Compound 4, dose for half-maximal effect: > 200 mg/kg
Compound 4 ended at the assay's limit (the forecaster's own chance of this, stated with the estimate: 5%); middle value at least 9.0-fold (0.95 log units) away from the limit.
By their numbers in this assay, from the lowest: compounds 3, 2 and 1 (each within the scatter of the next). At a limit, above all of these: compound 4.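

Among these side chains, only the 3-aminopropyl chain of compound 4 produces a change at this position that lies beyond the scatter. The step of an at least 10-fold higher number from compound 3 to compound 4 (1.00 log units; beyond the scatter) is matched by an at least 6.2-fold higher number from compound 2 to compound 4 (0.79 log units; beyond the scatter) and by an at least 5.7-fold higher number from compound 1 to compound 4 (0.75 log units; beyond the scatter) so small reshaping of the amine side chain is not always harmless. In this assay compound 4 gives > 200 mg/kg and this is a limit of the assay, not a number, so each step gives only a minimum size: the limit of > 200 mg/kg in this assay, at which 1 of the 4 values shown sits.

A shorter 2-aminoethyl chain on the same aromatic carbon would show whether the effect appears gradually with chain length. A 3-(methylamino)propyl chain would show whether a methyl on the amine nitrogen changes the outcome.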